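A few compounds are considered here, and "the series" means these few. Any claim that something is new, unique, unknown or untested is made for them only; others in the source may bear on it.

Measured compounds: compound 1 `O=C(CC1CCCCC1)N1CCN(c2nc(=O)c3cc(C(F)(F)F)cc([N+](=O)[O-])c3s2)CC1`, compound 2 `Cc1ccc(C(=O)N2CCN(c3nc(=O)c4cc(C(F)(F)F)cc([N+](=O)[O-])c4s3)CC2)cc1` and compound 3 `O=C(C1CCCCC1)N1CCN(c2nc(=O)c3cc(C(F)(F)F)cc([N+](=O)[O-])c3s2)CC1`.

In an ADME assay on Vero cells (Chlorocebus sabaeus) for cytotoxicity, read by MTT assay, with a stated time of 72 h (a higher number here means that more compound is tolerated, a lower number that less compound is tolerated), compound 1 gives only a limit, > 125000 nM. In this assay compound 2 likewise reaches only a limit, > 125000 nM. Compound 3 gives a number in this assay, 88700 nM, and the limit of > 125000 nM in this assay, at which 2 of the 3 values shown sit, marks where two of the three values sit. Compound 4 `O=C(C1CCCC1)N1CCN(c2nc(=O)c3cc(C(F)(F)F)cc([N+](=O)[O-])c3s2)CC1` has not been measured; it differs from compound 2 by cyclopentyl in place of 4-methylphenyl on a carbonyl carbon. The step that bears most on this is an at least 1.4-fold lower number from compound 2 to compound 3 (0.14 log units; that floor lies within the scatter), with an at least 1.4-fold lower number from compound 1 to compound 3 (0.14 log units; that floor lies within the scatter) pointing the same way, and the step that the two limits leave unreadable from compound 1 to compound 2 cannot be read. Compound 4 is therefore expected to land near compound 3, with the step of an at least 1.3-fold lower number from compound 2 to compound 4 (0.11 log units; that floor lies within the scatter) expected. For compound 4 the estimate is 95000 nM, within 45000 nM to 190000 nM.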

Compound 4, half-maximal cytotoxic concentration: 120000 nM
Compound 4: middle estimate off by 1.3-fold (0.10 log units), on the low side, within the range that was stated.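

In this assay, cyclopentyl and cyclohexyl on the carbonyl carbon do not separate, with a 1.4-fold higher number from compound 3 to compound 4 (0.13 log units; within the scatter). Against the two compounds held at a limit only floors exist, an at least 1.0-fold lower number from compound 2 to compound 4 (0.01 log units; that floor lies within the scatter) and an at least 1.0-fold lower number from compound 1 to compound 4 (0.01 log units; that floor lies within the scatter), so cyclopentyl cannot be ranked against 4-methylphenyl or cyclohexylmethyl. The reading at this position is capped by the assay limit: the limit of > 125000 nM in this assay, at which 2 of the 4 values shown sit.

On these data alone, whether any group at this position moves the number beyond the scatter remains open. An amine or a carboxylic acid on the group attached to this carbonyl carbon could answer that.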